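Aromatic substituent on the piperazine nitrogen

A few compounds are considered here, and "the series" means these few. Any claim that something is new, unique, unknown or untested is made for them only; others in the source may bear on it.

Three compounds share one core and differ only in the amine on the aromatic carbon: compound 1 `Cc1n[nH]c(C)c1Oc1c(O)cc(O)c2c(=O)cc(-c3ccc(N4CCCNCC4)cc3)oc12`, compound 2 `Cc1n[nH]c(C)c1Oc1c(O)cc(O)c2c(=O)cc(-c3ccc(N4CCN(c5ccccc5)CC4)cc3)oc12` and compound 3 `Cc1n[nH]c(C)c1Oc1c(O)cc(O)c2c(=O)cc(-c3ccc(N4CCN(C(C)C)CC4)cc3)oc12`. In an assay on cells for inhibition of ubiquitin carboxyl-terminal hydrolase 8 (Homo sapiens), read by fluorescence, with a stated time of 30 min (on this read-out higher numbers stand for weaker inhibition and lower numbers for stronger inhibition), compound 1 gives 17600 nM, compound 2 gives 3500 nM and compound 3 gives 16300 nM. Compound 3 sits with compound 1 within the scatter and well above compound 2. Going by the values given here, the steps are a 5.0-fold lower number from compound 1 to compound 2 (0.70 log units; beyond the scatter) and a 1.1-fold lower number from compound 1 to compound 3 (0.03 log units; within the scatter), so the one change that moved the number was a 4.7-fold higher number from compound 2 to compound 3 (0.67 log units; beyond the scatter).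

Compound 4 `Cc1n[nH]c(C)c1Oc1c(O)cc(O)c2c(=O)cc(-c3ccc(N4CCN(c5ccccn5)CC4)cc3)oc12` is not yet measured. Its change from compound 3 is pyridin-2-yl in place of isopropyl on an amine nitrogen in a ring. Among the compounds with values here, the step that bears on it is the one from compound 2 to compound 3 read backwards, where an aromatic ring on that nitrogen went with the lower number, while compound 1 and compound 3 show that amines without such a ring sit at the upper end. A drop in the direction of compound 2 is therefore expected, of about the size of that step. The expected step for compound 4 is a 4.1-fold lower number from compound 3 to compound 4 (0.61 log units; beyond the scatter). The estimate for compound 4 in this assay is 4000 nM, within 1500 nM to 11000 nM.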

Compound 4, half-maximal inhibitory concentration: 1200 nM
Compound 4: middle estimate off by 3.3-fold (0.52 log units), on the high side; the whole stated range lies above it.
By their numbers in this assay, from the lowest: compound 4; then compound 2; then compounds 3 and 1 (each within the scatter of the next).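

In this assay, going by these compounds alone, the aromatic ring on this amine nitrogen proves not to be interchangeable: with a 2.9-fold lower number from compound 2 to compound 4 (0.46 log units; beyond the scatter) the step lies beyond the scatter, and the earlier compounds, with phenyl as the only ring at this place, could not show that. Against the amines without an aromatic ring the gain is also larger than phenyl alone had shown, with a 14-fold lower number from compound 3 to compound 4 (1.13 log units; beyond the scatter) and a 15-fold lower number from compound 1 to compound 4 (1.17 log units; beyond the scatter) as the two steps. Nothing available accounts for the difference between pyridin-2-yl and phenyl.

Open, from the compounds shown here alone, is whether the ring nitrogen must sit as it does in pyridin-2-yl, which pyridin-3-yl, pyridin-4-yl or pyrimidin-2-yl on the same piperazine nitrogen would address. Also open, going by these compounds, is whether pyridin-2-yl carries over to the 1,4-diazepan-1-yl amine of compound 1.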